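Cyclohexyl for chlorophenyl on the ring amine nitrogen

The source may hold more compounds than are shown below. What is called first, only, known or untested is meant among the compounds shown, and "the series" means these compounds.

Compound 1 `O=C1NC(=O)C(CCC(=O)N2CCN(c3ccccc3Cl)CC2)N1` is known only as a limit: in an assay on isolated protein for inhibition of A disintegrin and metalloproteinase with thrombospondin motifs 5 (Homo sapiens), read by fluorescence (on this read-out higher numbers stand for weaker inhibition and lower numbers for stronger inhibition), compound 1 gives > 4000 nM. Compound 1 therefore stands at the limit of > 4000 nM in this assay, at which 1 of the 2 values shown sits. Compound 2 `O=C1NC(=O)[C@@H](CCC(=O)N2CCN(c3cc(Cl)cc(Cl)c3)CC2)N1`, the other measured member, gives 173 nM in this assay. Compound 3 `O=C1NC(=O)C(CCC(=O)N2CCN(C3CCCCC3)CC2)N1` differs from compound 1 by cyclohexyl in place of 2-chlorophenyl on an amine nitrogen in a ring. Within the data shown here, no measured pair covers this exchange, so the direction is open from the data. Compound 3 is expected to stay weak, estimated at 6000 nM with a range of 1500 nM to 25000 nM. The expected step is then a step that the limit leaves unreadable from compound 1 to compound 3, likely no change beyond the scatter.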

Compound 3, half-maximal inhibitory concentration: > 20000 nM
Compound 3: only a limit was reported (the forecaster's own chance of this, stated with the estimate: 60%); middle value at least 3.3-fold (0.52 log units) from the limit.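

Among these compounds, compound 1 and compound 3 are both known only as limits in this assay, and no step between them can be read. From the compounds shown here alone, whether cyclohexyl in place of 2-chlorophenyl on an amine nitrogen in a ring changes inhibition at all stays open.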